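The source may hold more compounds than are shown below. What is called first, only, known or untested is meant among the compounds shown, and "the series" means these compounds.

Measured so far in an ADME assay on the whole organism (Rattus norvegicus) for pharmacokinetics, using cassette dosing, at a dose of 1 mg/kg by the oral route; a lower number here means that a smaller share of the oral dose reaches the circulation, a higher number that a larger share of the oral dose reaches the circulation:
- compound 1 `C[C@@H](Cn1c(=O)[nH]/c(=N\c2ccc(Oc3nccs3)cc2)n(Cc2ccc(Cl)cc2)c1=O)C(=O)O` gives 41.4%
- compound 2 `C[C@@H](Cn1c(=O)[nH]/c(=N\c2ccc(Oc3cnccn3)cc2)n(Cc2ccc(Cl)cc2)c1=O)C(=O)O` gives 56.5%
- compound 3 `C[C@@H](Cn1c(=O)[nH]/c(=N\c2ccc(Oc3ccccn3)cc2)n(Cc2ccc(Cl)cc2)c1=O)C(=O)O` gives 52.8%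

Compound 3 stands level with compound 2 (a number 3.7 percentage points lower from compound 2 to compound 3 (within the scatter)) and clear of compound 1 (a number 11.4 percentage points higher from compound 1 to compound 3 (beyond the scatter)). Compound 4 `C[C@@H](Cn1c(=O)[nH]/c(=N\c2ccc(OC3CCC3)cc2)n(Cc2ccc(Cl)cc2)c1=O)C(=O)O` differs from compound 3 by cyclobutyl in place of pyridin-2-yl on an oxygen on an aromatic ring, with cyclobutyl in place of pyridin-2-yl on an oxygen on an aromatic ring. The nearest evidence is the exchange of one aromatic ring for another at that oxygen, the largest being a number 15.1 percentage points higher from compound 1 to compound 2 (beyond the scatter). Going by the values given here, no measured compound carries a non-aromatic ring there, so only a step of similar size is expected, leaning slightly downward, and possibly none beyond the scatter. The estimate means a number 6.8 percentage points lower from compound 3 to compound 4 (within the scatter) as the expected step. For compound 4 the estimated value is 46%, expected between 28% and 64%.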

Compound 4, oral bioavailability: 54.3%
The estimate for compound 4 lay 8.3 percentage points below the measured number, within the range that was stated.
By their numbers in this assay, from the lowest: compound 1; then compounds 3, 4 and 2 (each within the scatter of the next).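

In this assay the cyclobutyl ring on the oxygen does as well as the two six-membered aromatic rings (a number 1.5 percentage points higher from compound 3 to compound 4 (within the scatter); a number 2.2 percentage points lower from compound 2 to compound 4 (within the scatter)) and stands clear of 1,3-thiazol-2-yl (a number 12.9 percentage points higher from compound 1 to compound 4 (beyond the scatter)). An aromatic ring on this oxygen is therefore not required for the oral exposure seen here, and among these four compounds only the 1,3-thiazol-2-yl compound stands apart. Nothing available explains this result. The compounds shown leave open how a longer alkyl chain, or a saturated ring carrying an amine, would fare on this oxygen.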